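Methoxy for Trifluoromethyl on a Diaryl Urea Series

The compounds below may be only part of what the source reports. "The series", "measured", "known", "first", "only" and "open" are said of these compounds alone.

Measured compounds:
compound 1 `COc1ccc(C(F)(F)F)cc1Nc1cc(NC(=O)Nc2c(Cl)cccc2Cl)ncn1` gives 69.1%;
compound 2 `COc1cc(Nc2cc(NC(=O)Nc3c(Cl)cccc3Cl)ncn2)cc(OC)c1` gives 68%;
compound 3 `COc1cc(Nc2cc(NC(=O)Nc3c(Cl)cccc3Cl)ncn2)cc(C(F)(F)F)c1` gives 32.3%.

All three were tested in a functional assay on NCI-H1581 cells (Homo sapiens) for inhibition, read by MTT assay, with a stated time of 48 h, tested at 10 uM; a lower number here means less inhibition, a higher number more inhibition at the concentration tested (going by the name of the read-out). Compound 1 and compound 2 sit close together, while compound 3 gives a far lower reading. The change from compound 3 to compound 2 is methoxy in place of trifluoromethyl on an aromatic carbon, and it produced a number 35.7 percentage points higher from compound 3 to compound 2 (beyond the scatter). The cores of compound 1 and compound 3 differ in a way that is not broken down here.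

Compound 4 `COc1ccc(OC)c(Nc2cc(NC(=O)Nc3c(Cl)cccc3Cl)ncn2)c1` is not yet measured. It arises from compound 1 by methoxy in place of trifluoromethyl on an aromatic carbon, the same kind of change as from compound 3 to compound 2, but here the place is para to a methoxy group rather than meta to one. Because compound 1 already gives 69.1%, a reading near compound 2 is expected, so the step is estimated as a number 1.1 percentage points lower from compound 1 to compound 4 (within the scatter). Compound 4 is expected to give 68%.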

Compound 4, a percentage reported as inhibition, at one concentration (the size of the read-out at that concentration, not a potency): 93.1%
The estimate for compound 4 lay 25.1 percentage points below the measured number; measured number above the stated range.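

In this assay, methoxy in place of trifluoromethyl gave a number 24 percentage points higher from compound 1 to compound 4 (beyond the scatter). The same swap therefore raised the reading on both cores, and the size of the rise did not differ beyond the scatter: the same change on two cores in this assay, a number 35.7 percentage points higher (beyond the scatter) from compound 3 to compound 2 and a number 24 percentage points higher (beyond the scatter) from compound 1 to compound 4, 11.7 percentage points apart, within the scatter of two such steps

This shows that the change carried over between these two cores, but two pairs cannot show that it would do so on any other core, and they do not explain why the reading rises.

The compounds shown leave open how an amine, a carboxylic acid or a longer chain such as ethoxy would read at this place. They also leave open how the compounds compare in potency, since each reading comes from a single concentration.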